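Carbamoyl in Place of the Difluoroacetamido Chain

A few compounds are considered here, and "the series" means these few. Any claim that something is new, unique, unknown or untested is made for them only; others in the source may bear on it.

Going by the values given here, compound 2 `O=C(NC[C@H]1CN(c2ccc(-n3cc(-c4ccccn4)cn3)c(F)c2)C(=O)O1)C(F)F` is the only compound that gives a number in an ADME assay on HEK293-A cells (Homo sapiens) for cytotoxicity, read by MTT assay, with a stated time of 48 h; on this read-out higher numbers stand for weaker inhibition and lower numbers for stronger inhibition; there compound 2 gives 167 ug/mL. Compound 1 `COC[C@H]1CN(c2ccc(-n3cc(-c4ccccn4)cn3)c(F)c2)C(=O)O1` reaches only a limit in this assay, at > 400 ug/mL. Among the compounds with values here, the one measured step, an at least 2.3-fold lower number from compound 1 to compound 2 (0.37 log units; beyond the scatter), is all that bears on the next change. Compound 3 `NC(=O)[C@H]1CN(c2ccc(-n3cc(-c4ccccn4)cn3)c(F)c2)C(=O)O1` carries carbamoyl in place of (((difluoromethyl)carbonyl)amino)methyl on a saturated ring carbon. Within the data shown here, because the only measured step of an at least 2.3-fold lower number from compound 1 to compound 2 (0.37 log units; beyond the scatter) ran toward lower numbers as the acylated chain entered, removing it is expected to raise the number again, a 1.8-fold higher number from compound 2 to compound 3 (0.25 log units; within the scatter), possibly back to the limit of > 400 ug/mL in this assay, at which 1 of the 2 values shown sits. Compound 3 is thus estimated at 300 ug/mL, between 120 ug/mL and 450 ug/mL.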

Compound 3, half-maximal inhibitory concentration: 152 ug/mL
Compound 3: the middle estimate sits 2.0-fold (0.30 log units) above what was measured, within the range that was stated.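

In this assay the shorter carbamoyl on this saturated ring carbon gives a 1.1-fold lower number from compound 2 to compound 3 (0.04 log units; within the scatter) and so cannot be told apart from the (((difluoromethyl)carbonyl)amino)methyl chain. Set against methoxymethyl, carbamoyl gives an at least 2.6-fold lower number from compound 1 to compound 3 (0.42 log units; beyond the scatter) and thus shows that the lower number does not require the difluoroacetyl part or the longer chain. As far as these compounds go, the true size of that step stays open on one side, as compound 1 gives only a limit: the limit of > 400 ug/mL in this assay, at which 1 of the 3 values shown sits.

From the compounds shown here alone, it remains open whether an aminomethyl group or a carboxylic acid on this carbon would hold the number of compound 3 or return it to the limit.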